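Swapping an Aminoethyl for an Aminophenyl Ester

This account rests on a few compounds, and the source may have more. Where it says the series, first, only, none or still open, it means among the compounds named here.

Measured compounds:
Compound 1 `Cc1c(C)c2c(c(C)c1OC(=O)CCN)CC(CCn1ccc(=O)c(O)c1C)O2` gives 10000 ug/mL in an ADME assay for solubility; a higher number here means a more soluble compound, a lower number a less soluble compound.
Compound 2 `Cc1c(C)c2c(c(C)c1OC(=O)c1ccc(N)cc1)CC(CCn1ccc(=O)c(O)c1C)O2` sits at the limit < 100 ug/mL of this assay, a limit rather than a number.
Compound 3 `Cc1c(OC(=O)CCN)c(=O)ccn1CCCc1cc(C(C)(C)C)c(O)c(C(C)(C)C)c1` sits at the limit > 20000 ug/mL of this assay, again a limit rather than a number.

The change from compound 1 to compound 2 is 4-aminophenyl in place of 2-aminoethyl on a carbonyl carbon, and the step it made was an at least 100-fold lower number from compound 1 to compound 2 (2.00 log units; beyond the scatter). The cores of compound 1 and compound 3 differ in more than one place, and that difference is not broken down here. Compound 4 `Cc1c(OC(=O)c2ccc(N)cc2)c(=O)ccn1CCCc1cc(C(C)(C)C)c(O)c(C(C)(C)C)c1` carries the same change on the core of compound 3, namely (4-aminophenyl in place of 2-aminoethyl on a carbonyl carbon), at a place described in the same words as before. A drop of similar size is expected, an at least 330-fold lower number from compound 3 to compound 4 (2.52 log units; beyond the scatter), resting on the step of an at least 100-fold lower number from compound 1 to compound 2 (2.00 log units; beyond the scatter) seen for compound 2. For compound 4 the expected solubility is therefore 60 ug/mL, likely between 5 ug/mL and 600 ug/mL.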

Compound 4, solubility: < 100 ug/mL
Compound 4 ended at the assay's limit (the forecaster's own chance of this, stated with the estimate: 55%); the middle value is on the limit's open side.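

Carried to the second core, the swap of 2-aminoethyl for 4-aminophenyl on a carbonyl carbon again brought a large fall in this assay, an at least 200-fold lower number from compound 3 to compound 4 (2.30 log units; beyond the scatter). The change therefore pushed the number down on both cores shown, and the two steps compare as follows: the same change on two cores in this assay, an at least 100-fold lower number (2.00 log units; beyond the scatter) from compound 1 to compound 2 and an at least 200-fold lower number (2.30 log units; beyond the scatter) from compound 3 to compound 4; the limit leaves it open whether they differ Both steps rest on limits of the assay rather than on numbers, so their true sizes remain unknown, and two cores are too few to establish a rule for the whole series.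

The compounds shown leave open how a longer chain carrying an amine or a carboxylic acid would behave on this carbonyl carbon. They also leave open what a plain phenyl, without its amine, would give on either core.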